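A morpholin-4-yl carbonyl in place of methoxycarbonyl

A few compounds are considered here, and "the series" means these few. Any claim that something is new, unique, unknown or untested is made for them only; others in the source may bear on it.

Among the compounds with values here, in a functional assay on A549 cells (Homo sapiens) for inhibition, read by sulforhodamine B assay, with a stated time of 72 h (a higher number here means a weaker inhibitor of growth, a lower number a stronger inhibitor of growth), compound 2 (`COC(=O)/C=C/c1ccncc1-c1ccc2ccccc2c1`) gives 760 nM, the lowest of the two numbers so far, while compound 1 (`CNC(=O)/C=C/c1ccncc1-c1ccc2ccccc2c1`) gives 6620 nM. The next compound, compound 3 (`O=C(/C=C/c1ccncc1-c1ccc2ccccc2c1)N1CCOCC1`), carries morpholin-4-yl in place of methoxy on a carbonyl carbon. Within the data shown here, one measured step bears on this change, and it lies beyond the scatter: an 8.7-fold lower number from compound 1 to compound 2 (0.94 log units; beyond the scatter). That step also exchanges the group on the carbonyl carbon, with methoxy in place of methylamino. Compound 3 returns to a nitrogen-linked group there, so a step of similar size towards a higher number is expected. Among the measured compounds shown here, no compound with a ring at this place has been measured, which leaves the expectation wide. The expected change is a 5.3-fold higher number from compound 2 to compound 3 (0.72 log units; beyond the scatter). Compound 3 is estimated at 4000 nM, within an expected range of 1200 nM to 14000 nM.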

Compound 3, concentration for 50% growth inhibition: 8410 nM
For compound 3 the middle estimate is 2.1-fold (0.32 log units) below the measured one; the measured number falls inside the stated range.
By their numbers in this assay, from the lowest: compound 2; then compounds 1 and 3 (each within the scatter of the next).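

In this assay morpholin-4-yl in place of methoxy on a carbonyl carbon brings an 11-fold higher number from compound 2 to compound 3 (1.04 log units; beyond the scatter) and this large step gives methoxy a second nitrogen-linked comparison, after methylamino. Morpholin-4-yl in place of methylamino brings a 1.3-fold higher number from compound 1 to compound 3 (0.10 log units; within the scatter) so the ring and the smaller methylamino group cannot be told apart at this place, and both nitrogen-linked groups stand apart from methoxy with no compound shown going against that. Nothing available accounts for this difference.

Going by these compounds, whether the lower number belongs to methoxy alone or extends to other oxygen-linked groups remains open, and an ethoxy group or a carboxylic acid at this place would bear on that. On these data alone, whether any nitrogen-linked group can match methoxy also remains open, for example a primary amide or piperidin-1-yl.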